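Removing a methyl from a weak growth inhibitor

This account rests on a few compounds, and the source may have more. Where it says the series, first, only, none or still open, it means among the compounds named here.

Three compounds were tested in a functional assay on NSCLC cells (Homo sapiens) for cytotoxicity, with a stated time of 48 h; a lower number here means a stronger inhibitor of growth, a higher number a weaker inhibitor of growth. Compound 1 `COc1c(/C=C2/C(=O)Nc3ccc(Cl)cc32)c2ccccc2n1-c1ccccc1` gives 24600 nM, compound 2 `COc1cc2c(cc1C)NC(=O)/C2=C/c1c(Cl)n(Cc2cc(OC)c(OC)c(OC)c2)c2cc(C)c(OC)cc12` gives 66100 nM, and compound 3 `O=C1/C(=C/c2c(Cl)[nH]c3ccccc23)c2ccccc2N1Cc1ccccc1` gives 85100 nM. Among these three numbers compound 2 stands second highest: its value and that of compound 3 lie within the usual scatter of each other, while compound 1 gives a lower number, a gap beyond the scatter. Compound 4 `COc1ccc2c(c1)/C(=C\c1c(Cl)n(Cc3cc(OC)c(OC)c(OC)c3)c3cc(C)c(OC)cc13)C(=O)N2` differs from compound 2 in one place: hydrogen in place of methyl on an aromatic carbon. Among the compounds with values here, with no step between measured compounds to lean on, only a small change is expected in this assay, in no particular direction, so the estimate means a step of a 1.1-fold lower number from compound 2 to compound 4 (0.04 log units; within the scatter). Compound 4 is therefore expected to give about 60000 nM, with a range from 25000 nM to 150000 nM.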

Compound 4, concentration for total growth inhibition: 97700 nM
Compound 4: middle estimate off by 1.6-fold (0.21 log units), on the low side; the measured number falls inside the stated range.
By their numbers in this assay, from the lowest: compound 1; then compounds 2, 3 and 4 (each within the scatter of the next).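

In this assay, putting hydrogen in place of methyl on this aromatic carbon, ortho to a methoxy group, gives a 1.5-fold higher number from compound 2 to compound 4 (0.17 log units; within the scatter). Within the data shown here, this is the first direct reading at this position, and it shows that the methyl can be lost without a shift beyond the scatter. No measurement bears on why the two compounds read alike.

Still open, on these data alone, is whether a larger or different group on this carbon, such as an amine, a carboxylic acid or a longer chain, would move the number beyond the scatter.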